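This account rests on a few compounds, and the source may have more. Where it says the series, first, only, none or still open, it means among the compounds named here.

Compound 3 `CC[C@@H]1C(=O)N(C)c2cnc(-n3ccc4cc(C(=O)NCC(C)C)ccc43)nc2N1C1CCCC1` is reported in a functional assay on NCI-H1975 cells (Homo sapiens) for antiproliferative activity, read by CCK-8 assay, with a stated time of 72 h (on this read-out lower numbers stand for stronger inhibition of growth and higher numbers for weaker inhibition of growth), only as "not active" (no number reported), with no number attached, so it stands outside the range of the measured compounds. Compound 4 `CC[C@@H]1C(=O)N(C)c2cnc(-n3ccc4cc(C(N)=O)ccc43)nc2N1C1CCCC1` differs from it by hydrogen in place of isobutyl on an amide-type nitrogen. Among the measured compounds shown here, the only related step comes from compound 1 `CCC1C(=O)N(C)c2cnc(-n3ccc4cc(C(=O)NC)ccc43)nc2N1c1ccn(C)n1`, which gives 35700 nM in this assay, and compound 2 `CCCCNC(=O)c1ccc2c(ccn2-c2ncc3c(n2)N(c2ccn(C)n2)C(CC)C(=O)N3C)c1`, which gives 12000 nM; there the change was a 3.0-fold lower number from compound 1 to compound 2 (0.47 log units; beyond the scatter). The change from compound 3 to compound 4 runs the opposite way, shortening the amide substituent, so no gain is expected and a weaker result, if any number appears at all, seems likely. Compound 4 is therefore estimated at 60000 nM, within 20000 nM to 200000 nM, with a high chance that only a limit is reported.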

Compound 4, concentration for 50% growth inhibition: 3380 nM
For compound 4 the middle estimate is 18-fold (1.25 log units) above the measured one, and the stated range ends above it.
By their numbers in this assay, from the lowest: compound 4; then compound 2; then compound 1.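

In this assay, among the compounds shown here, compound 3 has no number, so no step to compound 4 can be read. The compounds shown leave open how far replacing isobutyl with hydrogen on the amide-type nitrogen changes growth inhibition. Nothing shown bears on a cause for this result.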